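Oxazole-to-imidazole swap on the biaryl anilide series

A few compounds are considered here, and "the series" means these few. Any claim that something is new, unique, unknown or untested is made for them only; others in the source may bear on it.

Two compounds in this series have numbers. Compound 1 `CC(C)c1ccc(OCC(=O)Nc2cccc(-c3nc4ncccc4o3)c2)cc1` gives 2100 nM in an assay on brain for inhibition of Fatty-acid amide hydrolase 1 (Rattus norvegicus); a higher number here means a weaker inhibitor, a lower number a stronger inhibitor. Compound 2 `O=C(COc1ccc(-c2ccccc2)cc1)Nc1ccc(-c2nc3ncccc3o2)cc1` gives 350 nM in this assay, the lowest of the two numbers, with compound 1 higher and beyond the scatter. Going by the values given here, no pair differing in a single place has been measured, so no step size is known.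

Compound 3 `O=C(COc1ccc(-c2ccccc2)cc1)Nc1ccc(-c2nc3ncccc3[nH]2)cc1` is the untested analogue of compound 2. It carries a group of 9 heavy atoms (6 carbon, 3 nitrogen; one five-membered aromatic ring with 2 hetero atoms, one six-membered aromatic ring with 1 hetero atom) in place of a group of 9 heavy atoms (6 carbon, 2 nitrogen, 1 oxygen; one five-membered aromatic ring with 2 hetero atoms, one six-membered aromatic ring with 1 hetero atom), on an aromatic carbon, on an aromatic carbon of a six-membered aromatic ring of carbon only, para to a large group. Among the compounds with values here, no measured pair shows what such a swap does here, so the expected step from compound 2 to compound 3, a 2.3-fold higher number from compound 2 to compound 3 (0.36 log units; beyond the scatter), is taken as modest and toward a higher number, with a wide range. The estimate for compound 3 in this assay is 800 nM, between 150 nM and 4000 nM.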

Compound 3, half-maximal inhibitory concentration: 620 nM
Beside the measured number, compound 3's estimate is 1.3-fold (0.11 log units) above it; measured number inside the range.
By their numbers in this assay, from the lowest: compounds 2 and 3 (each within the scatter of the next); then compound 1.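

Going by these compounds alone, at the aromatic carbon para to a large group, the first single-place step is now known: in this assay, replacing the group of 9 heavy atoms with 6 carbon, 2 nitrogen and 1 oxygen by the group with 6 carbon and 3 nitrogen gives a 1.8-fold higher number from compound 2 to compound 3 (0.25 log units; within the scatter). This step lies within the scatter, so the swap, which also moves the count from 0 to 1 hydrogen-bond donor and from 3 to 2 acceptors, leaves no measurable difference in this assay. Nothing on hand gives a reason for this result.

Still open, from the compounds shown here alone, is whether a methyl on the ring nitrogen of the entering group would leave the number as flat. Also open, going by these compounds, is what an amine or a carboxylic acid would do at this aromatic carbon in place of the whole group.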